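Moving the acetyl group on the aniline ring of compound 1

A few compounds are considered here, and "the series" means these few. Any claim that something is new, unique, unknown or untested is made for them only; others in the source may bear on it.

Measured compounds:
- compound 1 `CC(=O)c1cccc(Nc2ccnc(SCC(=O)c3ccc(-c4ccccc4)cc3)n2)c1`: 49%
- compound 2 `COc1ccc(C(=O)CSc2nccc(Nc3cccc(C(C)=O)c3)n2)cc1`: 45%

In a functional assay on T47D cells (Homo sapiens) for inhibition, read by sulforhodamine B assay, with a stated time of 48 h, tested at 10 uM (on this read-out lower numbers stand for less inhibition of growth and higher numbers for more inhibition of growth at the one concentration tested), compound 1 gives 49%, the higher of the two numbers, with compound 2 at 45%. The step of a number 4 percentage points lower from compound 1 to compound 2 (within the scatter) swaps methoxy for phenyl on an aromatic carbon. Compound 3 `CC(=O)c1ccc(Nc2ccnc(SCC(=O)c3ccc(-c4ccccc4)cc3)n2)cc1` differs from compound 1 elsewhere: 4-acetylphenyl in place of 3-acetylphenyl on a nitrogen on an aromatic ring. No measured step touches this part of the shared core, so nothing shown points to a change beyond the scatter. Compound 3 is therefore expected to come out near compound 1, at an estimated 49% within 30% to 66%, a step of no change at the digits printed from compound 1 to compound 3 (within the scatter).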

Compound 3, percent growth inhibition at one concentration: 29%
Estimate against measurement, compound 3: 20 percentage points above; measured number outside the range, below it.
By their numbers in this assay, from the lowest: compound 3; then compounds 2 and 1 (each within the scatter of the next).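

In this assay, 4-acetylphenyl in place of 3-acetylphenyl gives a number 20 percentage points lower from compound 1 to compound 3 (beyond the scatter) even though the two compounds contain the same atoms, joined differently. So, at the one concentration tested, growth inhibition depends on how the acetyl group is attached to this ring, which the earlier pair, differing elsewhere, could not show. Nothing available explains the drop. Still open, on these data alone, is whether an amine or a carboxylic acid in place of the acetyl group would hold the level of compound 1. Also open, as far as these compounds go, is whether the same drop would appear in compound 2, which carries methoxy in place of phenyl.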